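Ester in place of thioester on the shared core

This account rests on a few compounds, and the source may have more. Where it says the series, first, only, none or still open, it means among the compounds named here.

The series rests on one shared core. Compound 1 `CC1=C(C(=O)NC(C)C)C(c2ccoc2)NC(=O)N1` bears isopropylamino on the carbonyl carbon; compound 2 `CC1=C(C(=O)SC(C)C)C(c2ccoc2)NC(=O)N1` bears isopropylsulfanyl there. In an assay on membranes from CHO cells for displacement of a labelled ligand from adenosine receptor A1 (Homo sapiens), read by scintillation counting, with a stated time of 60 min, tested at 1 uM (on this read-out lower numbers stand for less inhibition and higher numbers for more inhibition at the one concentration tested (going by the name of the read-out)), compound 1 gives 1%, and compound 2 gives 9%. For the measured compounds named here, the one step measured, a number 8 percentage points higher from compound 1 to compound 2 (within the scatter), lies within the scatter, so the two numbers stand level with each other and no order can be read between them. On the numbers at hand compound 2 carries the highest figure of the two, with compound 1 nearest to it.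

Compound 3 `CC1=C(C(=O)OC2CCCC2)C(c2ccoc2)NC(=O)N1` has not yet been measured. It differs from compound 2 by cyclopentyloxy in place of isopropylsulfanyl on a carbonyl carbon. Going by the values given here, no measured step exchanges one sulfur- or oxygen-linked group for another on this carbonyl carbon; the only step available, a number 8 percentage points higher from compound 1 to compound 2 (within the scatter), swapped the amine for the sulfide and stayed within the scatter. On that basis a step no larger than the scatter is expected in this assay, with no direction called, and the expected step is a number 3 percentage points lower from compound 2 to compound 3 (within the scatter). For compound 3 the estimated value in this assay is 6%, expected to fall between -8% and 22%.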

Compound 3, a percentage reported as inhibition, at one concentration (the size of the read-out at that concentration, not a potency): 6%
Compound 3: middle estimate and measured number agree at the digits printed; the range from low to high includes it.
By their numbers in this assay, from the lowest: compounds 1, 3 and 2 (each within the scatter of the next).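

In this assay, cyclopentyloxy in place of isopropylsulfanyl on the carbonyl carbon gives a number 3 percentage points lower from compound 2 to compound 3 (within the scatter), and cyclopentyloxy in place of isopropylamino at the same carbon gives a number 5 percentage points higher from compound 1 to compound 3 (within the scatter). This position has now carried groups linked through nitrogen, sulfur and oxygen, and a five-membered non-aromatic ring of carbon only as well as an open isopropyl group, and neither of these two steps separates the compounds in this read-out, so the ring and the oxygen link show no effect that can be told from the scatter.

From the compounds shown here alone, whether a carboxylic acid, a primary amine or a longer chain such as n-hexyloxy on this carbonyl carbon would produce a step beyond the scatter stays open. Also open, going by these compounds, is whether the level numbers hold at any concentration other than the one tested, since a single-concentration read-out in this assay gives no potency. No measurement on hand accounts for the three compounds standing level.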